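This account rests on a few compounds, and the source may have more. Where it says the series, first, only, none or still open, it means among the compounds named here.

Measured compounds:
compound 1 `Cc1ccccc1-c1nn(-c2cccc(Cl)c2)cc1CNCCN1CCN(C)CC1` — 16000 nM in an ADME assay on Huh-7 cells (Homo sapiens) for cytotoxicity; on this read-out higher numbers stand for lower toxicity in this test and lower numbers for higher toxicity in this test
compound 2 `CN1CCN(CCNCc2cc(-c3ccccc3)nn2-c2ccc(F)cc2)CC1` — > 20000 nM, a limit of the assay

In this assay compound 1 gives 16000 nM, the only numerical value among the two results shown. Compound 2 stands at > 20000 nM, which is a limit of the assay rather than a number. That is the whole picture of the measured side: the limit of > 20000 nM in this assay, at which 1 of the 2 values shown sits, and one actual value, that of compound 1. For the measured compounds named here, no pair of measured compounds differs in a single place, so no measured step can be drawn between them.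

Compound 3 `Cc1ccccc1-c1nn(-c2cccc(C(F)(F)F)c2)cc1CNCCN1CCN(C)CC1` has not yet been measured in this assay. It is reached from compound 1 by trifluoromethyl in place of chloro on an aromatic carbon. The change is small in count and keeps the rest of the molecule unchanged. With nothing measured on a comparable step, the expected step from compound 1 to compound 3 is a 1.1-fold lower number from compound 1 to compound 3 (0.06 log units; within the scatter), that is, no change beyond the usual scatter in either direction. Compound 3 is therefore estimated at 14000 nM, with a range from 6000 nM to 30000 nM.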

Compound 3, half-maximal cytotoxic concentration: 18000 nM
Compound 3: middle estimate off by 1.3-fold (0.11 log units), on the low side; measured number inside the range.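

For the compounds shown here, this is the first measured step, and it concerns the aromatic carbon meta to a large group on the 3-chlorophenyl ring of compound 1. In this assay, trifluoromethyl in place of chloro gives a 1.1-fold higher number from compound 1 to compound 3 (0.05 log units; within the scatter), so the two compounds cannot be told apart on this read-out, even though trifluoromethyl carries more heavy atoms than chloro. At this position, then, this one exchange leaves the read-out where it was, while the rest of the molecule stays the same; the read-out also has a ceiling not far from both numbers, which leaves little room to register any step upward: the limit of > 20000 nM in this assay, at which 1 of the 3 values shown sits.

What the compounds shown leave open is whether this position tolerates groups of another kind, such as an amine, a carboxylic acid or a nitrile, as quietly as it tolerates these two. They also leave open whether the same exchange would read the same way on a different core, since a single step on the core of compound 1 says nothing about any other.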